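The compounds below may be only part of what the source reports. "The series", "measured", "known", "first", "only" and "open" are said of these compounds alone.

Compound 3, `COc1cc(C)cc(-c2nn(CC#N)cc2-c2ccnc(-c3ccc(N(C)C)cc3)c2)c1`, gives 672 nM in a functional assay on SK-MEL-5 cells (Homo sapiens) for inhibition, read by sulforhodamine B assay, with a stated time of 48 h (on this read-out lower numbers stand for stronger inhibition of growth and higher numbers for weaker inhibition of growth), the lowest number among the three compounds measured. Compound 1, `COc1cc(C)cc(-c2c(-c3ccnc(-c4ccc(C(C)=O)cc4)c3)cnn2CC#N)c1`, gives 4960 nM in this assay, and compound 2, `Cc1cc(O)cc(-c2nn(CC#N)cc2-c2ccnc(-c3ccc(Oc4ccccc4)cc3)c2)c1`, gives 9900 nM in this assay; both of these stand higher than compound 3 by more than the usual scatter, so compound 3 is the strongest of the three on this read-out. Compound 1 and compound 2 differ from compound 3 in more than one place, so their numbers show only where compound 3 stands, not what any single change did.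

Compound 4, `Cc1cc(O)cc(-c2nn(CC#N)cc2-c2ccnc(-c3ccc(N(C)C)cc3)c2)c1`, is the next step. It differs from compound 3 in one place: hydrogen in place of methyl on an oxygen on an aromatic ring. For the measured compounds named here, no measured pair shows this change on its own, so its effect is not fixed by the data; compound 2 carries the hydroxy group but also a different substituent on its far ring, and cannot separate the two.

Going by the values given here, with no direct precedent, the step from compound 3 to compound 4 is expected to be small, most likely within the usual scatter, with a slight lean toward a higher number, a 1.3-fold higher number from compound 3 to compound 4 (0.13 log units; within the scatter). Compound 4 is therefore estimated at 900 nM in this assay, within a range of 300 nM to 3000 nM.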

Compound 4, concentration for total growth inhibition: 5750 nM
For compound 4 the middle estimate is 6.4-fold (0.81 log units) below the measured one; the measured number lies above the stated range.
By their numbers in this assay, from the lowest: compound 3; then compounds 1, 4 and 2 (each within the scatter of the next).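

In this assay, the change from methoxy to hydroxy on the 3-methoxy-5-methylphenyl group now has a measured size of its own, an 8.6-fold higher number from compound 3 to compound 4 (0.93 log units; beyond the scatter), so the methyl on this oxygen counts for much of where compound 3 stands among these compounds. With the hydroxy group held in both compounds, dimethylamino in place of phenoxy on an aromatic carbon gives a 1.7-fold lower number from compound 2 to compound 4 (0.24 log units; within the scatter), so this pair shows no separable effect of that change, and the hydroxy compounds stand together on this read-out whichever of the two groups they carry. Nothing measured here accounts for the size of the methoxy to hydroxy step.

The compounds shown leave open whether dimethylamino and phenoxy would also stay within the scatter of each other with methoxy kept on the aromatic ring, since the one pair that compares them carries hydroxy. They also leave open whether the methyl on this oxygen can be replaced by a longer chain such as ethyl, or whether an amine or a fluorine in place of the methoxy would hold the number of compound 3.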